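From compound 2 to compound 3: an aryl exchange at the carbonyl

This account rests on a few compounds, and the source may have more. Where it says the series, first, only, none or still open, it means among the compounds named here.

Measured compounds:
compound 1, `COc1ccc(-c2cc(/C=C/C(=O)c3ccc(N)cc3)[nH]n2)cc1`: 88%
compound 2, `COc1cc(-c2cc(/C=C/C(=O)c3ccc(N)cc3)[nH]n2)cc(OC)c1OC`: 91%

In a functional assay on A498 cells (Homo sapiens) for cytotoxicity, read by sulforhodamine B assay, with a stated time of 48 h, tested at 0.01 uM (a higher number here means a weaker effect of the compound at the concentration tested, a lower number a stronger effect), compound 2 gives 91%, and compound 1 gives 88%; the two numbers lie within the scatter of each other, so neither stands apart. Compound 3, `COc1cc(-c2cc(/C=C/C(=O)c3ccc(Cl)c(Cl)c3)[nH]n2)cc(OC)c1OC`, differs from compound 2 by 3,4-dichlorophenyl in place of 4-aminophenyl on a carbonyl carbon. Going by the values given here, no measured pair shows what this exchange does, so the expected step of a number 2 percentage points lower from compound 2 to compound 3 (within the scatter) is none beyond the scatter. Compound 3 is therefore estimated at 89%, within 72% to 100%.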

Compound 3, a percentage reported as activity, at one concentration (the size of the read-out at that concentration, not a potency): 84%
Compound 3: the middle estimate sits 5 percentage points above what was measured; low and high end bracket the measured number.
By their numbers in this assay, from the lowest: compounds 3, 1 and 2 (each within the scatter of the next).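

In this assay the exchange of 4-aminophenyl for 3,4-dichlorophenyl on a carbonyl carbon gives a number 7 percentage points lower from compound 2 to compound 3 (within the scatter) and is the first change shown at this position. The step stays inside the scatter even though the group that enters has neither the hydrogen-bond donor nor the acceptor counted for the group that leaves. Nothing measured here offers an explanation for this result. From the compounds shown here alone, whether a carboxylic acid or a single chlorine in place of these groups would give a step beyond the scatter stays open. So does the behaviour of these compounds at higher concentrations.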